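A few compounds are considered here, and "the series" means these few. Any claim that something is new, unique, unknown or untested is made for them only; others in the source may bear on it.

Measured compounds in an ADME assay on RAW264.7 cells (Mus musculus) for cytotoxicity, read by MTT assay, with a stated time of 24 h, tested at 1.25 ug/mL; on this read-out higher numbers stand for a weaker effect at the one concentration tested and lower numbers for a stronger effect:
compound 1 `COc1ccc(/C=C/C(=O)c2ccc(OC)c(OC)c2)cc1`, 97.2%
compound 2 `COc1ccc(/C=C/C(=O)c2ccc(OC)c(OC)c2)cc1OC`, 94%
compound 3 `COc1ccc(C(=O)CCc2ccc(OC)c(OC)c2)c(O)c1`, 91.8%

All three numbers sit within the usual scatter of one another, so none of the three can be called more or less active than the others in this assay. Going by the values given here, the one change that can be followed between measured compounds is hydrogen in place of methoxy on an aromatic carbon, and it gave a number 3.2 percentage points higher from compound 2 to compound 1 (within the scatter). Compound 4 `COc1ccc(CCC(=O)c2ccc(OC)cc2O)cc1` differs from compound 3 by hydrogen in place of methoxy on an aromatic carbon, the same change at the same kind of place. How the core of compound 3 differs from the core of compound 2 is not broken down here. Because the earlier step was a number 3.2 percentage points higher from compound 2 to compound 1 (within the scatter), compound 4 is expected to stay close to compound 3, with an estimated step of a number 2.2 percentage points higher from compound 3 to compound 4 (within the scatter). For compound 4 the expected number in this assay is 94%, between 85% and 100%.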

Compound 4, a percentage reported as activity, at one concentration (the size of the read-out at that concentration, not a potency): 95.1%
For compound 4 the middle estimate is 1.1 percentage points below the measured one, and the stated range covers the measured number.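

In this assay, hydrogen in place of methoxy on an aromatic carbon gave a number 3.3 percentage points higher from compound 3 to compound 4 (within the scatter). Set side by side, the two steps show the change behaving alike on the two cores: the same change on two cores in this assay, a number 3.2 percentage points higher (within the scatter) from compound 2 to compound 1 and a number 3.3 percentage points higher (within the scatter) from compound 3 to compound 4, 0.1 percentage points apart, within the scatter of two such steps Both steps lie within the scatter, so this does not show that the change has any real effect on the read-out, and two cores cannot say how it would behave on a third.

The compounds shown leave open what an amine or a carboxylic acid would do in place of that methoxy. Going by these compounds, a longer chain on the same oxygen, such as ethoxy, also remains untested among them in this assay.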